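Pyrazolyl amide in place of the anilide on the shared core

The source may hold more compounds than are shown below. What is called first, only, known or untested is meant among the compounds shown, and "the series" means these compounds.

Compound 3 `Nc1ccc(C(=O)Nc2ccc(S(=O)(=O)N3CCCC3)cc2)c(Cl)c1` stands at the top of an ADME assay on Vero cells (Chlorocebus sabaeus) for cytotoxicity, read by MTT assay; a higher number here means that more compound is tolerated, a lower number that less compound is tolerated: compound 3 gives > 300000 nM, which is a limit of the assay, not a number. Compound 1 `O=C(Nc1ccc(S(=O)(=O)N2CCCC2)cc1)c1ccc(F)cc1` gives > 300000 nM, likewise a limit. Compound 2 `O=C(Nc1ccc(S(=O)(=O)N2CCCC2)cc1)c1ccc(Br)cc1` gives 59000 nM. Two of the three values thus rest at the limit (the limit of > 300000 nM in this assay, at which 2 of the 3 values shown sit). The change to compound 4 `Cc1cc(C(=O)Nc2ccc(S(=O)(=O)N3CCCC3)cc2)n(C)n1` is 1,3-dimethyl-1H-pyrazol-5-yl in place of 4-amino-2-chlorophenyl on a carbonyl carbon. Among the compounds with values here, the measured steps that swap the group on the carbonyl carbon are an at least 5.0-fold higher number from compound 2 to compound 3 (0.70 log units; beyond the scatter) and a step that the two limits leave unreadable from compound 1 to compound 3, both ending at the limit, while an at least 5.0-fold lower number from compound 1 to compound 2 (0.70 log units; beyond the scatter) is the only step readable on both ends. Compound 4 is therefore expected to remain near the limit, with an estimate of 250000 nM between 80000 nM and 300000 nM, an expected step of an at least 1.2-fold lower number from compound 3 to compound 4 (0.07 log units; that floor lies within the scatter).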

Compound 4, half-maximal cytotoxic concentration: > 300000 nM
Compound 4: a limit, no number; the forecaster's own chance of this, stated with the estimate: 65%; at least 1.2-fold (0.07 log units) between middle value and limit.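

In this assay, compound 4 also gives a limit and not a number, so a five-membered aromatic ring with 2 hetero atoms on the carbonyl carbon reaches the same limit as the six-membered rings of compound 1 and compound 3. Against the 4-bromophenyl group, the change reads as an at least 5.0-fold higher number from compound 2 to compound 4 (0.70 log units; beyond the scatter). The steps from compound 1 and from compound 3 to compound 4 cannot be read, since both ends of each are limits: the limit of > 300000 nM in this assay, at which 3 of the 4 values shown sit.

On these data alone, how compound 1, compound 3 and compound 4 rank beyond that limit stays open. Also open, as far as these compounds go, is whether an amine or a carboxylic acid in place of the 1,3-dimethyl-1H-pyrazol-5-yl group would stay at the limit.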